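The source may report more compounds than this note shows. Statements on the series, on what has been measured and on what is new or still open speak of the compounds shown alone.

In a functional assay on FaDu cells (Homo sapiens) for cytotoxicity, read by MTT assay, with a stated time of 72 h (a higher number here means that more compound is tolerated, a lower number that less compound is tolerated), compound 1 (`COc1ccc(NC(=O)C(=O)c2cn(C(C)C)c3c(Cl)cccc23)cn1`) gives 10200 nM. Compound 2 (`COc1ccc(NC(=O)C(=O)c2cn(C(C)(C)COCC(=O)O)c3ccccc23)cn1`) gives > 10000 nM, which is a limit of the assay. Compound 3 (`CCn1cc(C(=O)C(=O)Nc2ccnc(OC)c2)c2ccccc21`) gives 4180 nM, the lower of the two actual numbers, and the gap to compound 1 lies beyond the scatter. Compound 4 (`CCn1cc(C(=O)C(=O)Nc2ccc(OC)nc2)c2ccccc21`) keeps the core of compound 3 and changes only the group on the amide-type nitrogen: 6-methoxypyridin-3-yl in place of 2-methoxypyridin-4-yl on an amide-type nitrogen. Going by the values given here, compounds 1 and 2 also carry 6-methoxypyridin-3-yl, but each differs from compound 3 elsewhere too, so no measured pair isolates this change. No clear direction is expected, and the expected change, a 1.1-fold higher number from compound 3 to compound 4 (0.03 log units; within the scatter), stays within the scatter. For compound 4 the estimated value is 4500 nM, with an expected range of 1200 nM to 12000 nM.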

Compound 4, concentration lethal to 50% of the cells: 219 nM
For compound 4 the middle estimate is 21-fold (1.31 log units) above the measured one; the measured number lies below the stated range.
By their numbers in this assay, from the lowest: compound 4; then compound 3; then compound 1.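

In this assay, 6-methoxypyridin-3-yl in place of 2-methoxypyridin-4-yl on an amide-type nitrogen gives a 19-fold lower number from compound 3 to compound 4 (1.28 log units; beyond the scatter), so this position distinguishes two groups with the same atoms, joined differently. On the aromatic nitrogen, the smaller group of compound 4 in place of the larger group of compound 2 gives an at least 45-fold lower number from compound 2 to compound 4 (1.65 log units; beyond the scatter). Compound 2 stands at a limit: the limit of > 10000 nM in this assay, at which 1 of the 4 values shown sits.

Nothing shown explains the size of either step. Still open, as far as these compounds go, is whether a 6-aminopyridin-3-yl or a plain phenyl on the amide-type nitrogen would keep the number of compound 4.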